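Methoxy for Methyl on Two Related Fused Cores

This account rests on a few compounds, and the source may have more. Where it says the series, first, only, none or still open, it means among the compounds named here.

Compound 1 `Cc1cccc2c(NCc3ccco3)nc(NC(C)C)nc12` and compound 2 `Cc1ccc2c(NCc3ccco3)nc(NC(C)C)nc2c1` are built from the same atoms joined differently; the difference between the two cores is not broken down here. In a physicochemical assay for lipophilicity, at pH 7.4 (on this read-out lower numbers stand for lower lipophilicity and higher numbers for higher lipophilicity), compound 1 gives 3.55 and compound 2 gives 3.61, two values within the scatter of each other. Compound 3 `COc1cccc2c(NCc3ccco3)nc(NC(C)C)nc12` carries the change methoxy in place of methyl on an aromatic carbon relative to compound 1, and in this assay compound 3 gives 3.4, so that the step is a number 0.15 log units lower from compound 1 to compound 3 (within the scatter). Compound 4 `COc1ccc2c(NCc3ccco3)nc(NC(C)C)nc2c1` carries the change methoxy in place of methyl on an aromatic carbon relative to compound 2 and has not yet been measured in this assay. The change occurs twice among the compounds shown, and it is the same kind of change, not the same: in compound 3 the methoxy sits ortho to a fused ring and meta to a fused ring, while in compound 4 it sits meta to a fused ring and para to a fused ring. Because the measured step of a number 0.15 log units lower from compound 1 to compound 3 (within the scatter) stayed within the scatter, compound 4 is expected to show a step of a number 0.15 log units lower from compound 2 to compound 4 (within the scatter). Compound 4 is accordingly estimated at 3.46, with a range from 3.2 to 3.7.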

Compound 4, distribution coefficient: 3.7
For compound 4 the middle estimate is 0.24 log units below the measured one, within the range that was stated.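

In this assay the step on the core of compound 2 is a number 0.09 log units higher from compound 2 to compound 4 (within the scatter) and the step on the core of compound 1 is a number 0.15 log units lower from compound 1 to compound 3 (within the scatter) so on both cores, methoxy in place of methyl on an aromatic carbon leaves the read-out within the scatter. In that limited sense the result carries from one core to the other, and the opposite signs of the two steps carry no weight, as neither step can be told from repeat scatter. Among these compounds, this rests on only two pairs and does not show that the change would behave alike on any further core or on another aromatic carbon, and nothing available here accounts for the result.

The compounds shown leave open what an amine, a carboxylic acid or a longer chain such as ethoxy would do on the same aromatic carbon. They also leave open whether either core would then give a step beyond the scatter.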